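The source may report more compounds than this note shows. Statements on the series, on what has been measured and on what is new or still open speak of the compounds shown alone.

Going by the values given here, compound 2 `CCOC(=O)c1ccc(NC(=O)N2CC2C#N)cc1` is one of three compounds measured in a functional assay on OVCAR-3 cells (Homo sapiens) for inhibition; a higher number here means a weaker inhibitor, a lower number a stronger inhibitor. In this assay compound 2 gives 7700 nM, the highest of the two numbers recorded. The nearest is compound 1 `N#CC1CN1C(=O)Nc1ccc(Cl)c(Cl)c1`, and in this assay compound 1 gives 5600 nM, a gap that sits within the scatter of the method, so the two cannot be ranked against each other. Compound 3 `N#CC1CN1C(N)=O`, the smallest of the three, reached no number: in this assay compound 3 gives > 90000 nM, which is a limit of the assay (the limit of > 90000 nM in this assay, at which 1 of the 3 values shown sits). Compound 4 `N#CC1CN1C(=O)Nc1ccc(C(F)(F)F)cc1` differs from compound 2 in one place: trifluoromethyl in place of ethoxycarbonyl on an aromatic carbon. Among the compounds with values here, no measured pair isolates this kind of swap, so there is nothing to suggest a change of any size; the expected step of a 1.2-fold lower number from compound 2 to compound 4 (0.07 log units; within the scatter) is therefore small, within the scatter, with no clear direction. Compound 4 is expected to give 6500 nM in this assay, with a range from 2000 nM to 20000 nM.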

Compound 4, half-maximal inhibitory concentration: 5900 nM
Compound 4: the middle estimate sits 1.1-fold (0.04 log units) above what was measured; measured number inside the range.
By their numbers in this assay, from the lowest: compounds 1, 4 and 2 (each within the scatter of the next). At a limit, above all of these: compound 3.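

Trifluoromethyl in place of ethoxycarbonyl, on an aromatic carbon para to a group of 8 heavy atoms, gives in this assay a 1.3-fold lower number from compound 2 to compound 4 (0.12 log units; within the scatter). Going by these compounds alone, this is the first measured swap at this position, and it shows that two quite different groups can sit there without a change that the assay can resolve: ethoxycarbonyl has a double bond and hydrogen-bond acceptors, whereas trifluoromethyl has neither and carries fluorine in place of oxygen. Nothing measured here explains why the two groups give values so close together.

On these data alone, whether an amine, a carboxylic acid or a longer chain at this position would also leave the value unmoved remains open. So does the contribution of the nitrile, which all the compounds shown carry.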